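Methoxy for bromo on the azo-linked phenyl ring

A few compounds are considered here, and "the series" means these few. Any claim that something is new, unique, unknown or untested is made for them only; others in the source may bear on it.

Of the compounds shown here, three sharing one core have been tested in an ADME assay on MT4 cells (Homo sapiens) for cytotoxicity, read by MTT assay; a lower number here means that less compound is tolerated, a higher number that more compound is tolerated. Compound 1 `Cc1ccc(/N=N/c2sc(N3Nc4onc(-c5ccccc5)c4C3c3ccc(Cl)cc3)nc2C)cc1` gives 450 nM. Compound 2 `Cc1nc(N2Nc3onc(-c4ccccc4)c3C2c2ccc(Cl)cc2)sc1/N=N/c1ccc(Cl)cc1` gives 340 nM in this assay, and compound 3 `Cc1nc(N2Nc3onc(-c4ccccc4)c3C2c2ccc(Cl)cc2)sc1/N=N/c1ccc(Br)cc1` gives 390 nM. Compound 3 thus sits second highest of the three numbers, closest to compound 2 and furthest from compound 1, with both gaps within the scatter.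

Compound 4 `COc1ccc(/N=N/c2sc(N3Nc4onc(-c5ccccc5)c4C3c3ccc(Cl)cc3)nc2C)cc1` is reached from compound 3 by the change (methoxy in place of bromo on an aromatic carbon). The measured steps all concern the same position on that ring: a 1.3-fold lower number from compound 1 to compound 2 (0.12 log units; within the scatter), a 1.2-fold lower number from compound 1 to compound 3 (0.06 log units; within the scatter) and a 1.1-fold higher number from compound 2 to compound 3 (0.06 log units; within the scatter). Exchanging methyl, chloro and bromo there moved the numbers in this assay by no more than the scatter allows, so the position appears tolerant of small changes among the three compounds seen; no oxygen-bearing group has been placed there yet.

On that basis compound 4 is expected to remain close to its neighbours, with a step of a 1.1-fold higher number from compound 3 to compound 4 (0.04 log units; within the scatter) that does not exceed the scatter. The estimate for compound 4 in this assay is 430 nM, with a range from 200 nM to 950 nM.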

Compound 4, half-maximal cytotoxic concentration: 460 nM
The estimate for compound 4 lay 1.1-fold (0.03 log units) below the measured number; the range from low to high includes it.
By their numbers in this assay, from the lowest: compounds 2, 3, 1 and 4 (each within the scatter of the next).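

The 4-bromophenyl to 4-methoxyphenyl exchange puts an oxygen-bearing group at this place for the first time among these compounds, and in this assay it gives a 1.2-fold higher number from compound 3 to compound 4 (0.07 log units; within the scatter). Against the other two compounds at the same place, the methoxy group gives a 1.4-fold higher number from compound 2 to compound 4 (0.13 log units; within the scatter) and a 1.0-fold higher number from compound 1 to compound 4 (0.01 log units; within the scatter), so across all four compounds none of the exchanges on this aromatic carbon para to a large group goes beyond the scatter, and no compound goes against that reading; the tolerance seen for methyl, chloro and bromo therefore also covers a group of two heavy atoms that brings one hydrogen-bond acceptor. No supporting data are available to explain this result.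

Going by these compounds, whether the same tolerance in this assay would hold for an amine, a carboxylic acid or a longer chain such as butoxy at this place remains open. The four compounds differ only at this one place, so they also leave open how changes elsewhere on the shared core, such as replacing the chloro group on its other aromatic ring, would affect the number.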